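Azido to hydroxy on the sugar ring: cytotoxicity notes

A few compounds are considered here, and "the series" means these few. Any claim that something is new, unique, unknown or untested is made for them only; others in the source may bear on it.

Three compounds of this series have numbers in an ADME assay on HepG2 cells (Homo sapiens) for cytotoxicity, read by MTT assay, with a stated time of 3 days (on this read-out lower numbers stand for higher toxicity in this test and higher numbers for lower toxicity in this test), so far. Compound 1 `Cc1cn([C@@H]2C[C@@H](O)[C@H](CO)O2)c(=O)nc1N` sits at a limit of the assay, > 2000000 nM, and this is the only limit among the three values (the limit of > 2000000 nM in this assay, at which 1 of the 3 values shown sits). Compound 2 `[N-]=[N+]=N[C@@H]1C[C@@H](n2ccc(NO)nc2=O)O[C@H]1CO` gives 1160000 nM, the lowest of the two plain numbers. Its nearest number belongs to compound 3 `O=c1nc(NO)ccn1[C@@H]1C=C[C@H](CO)O1`, which gives 2500000 nM in this assay, higher than compound 2 and beyond the scatter.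

The next compound, compound 4 `O=c1nc(NO)ccn1[C@@H]1C[C@@H](O)[C@H](CO)O1`, differs from compound 2 by hydroxy in place of azido on a saturated ring carbon. No step between two measured compounds of this series isolates that change, so the expectation rests on the spread of the numbers shown. For compound 4 the expectation is a step of a 1.7-fold higher number from compound 2 to compound 4 (0.24 log units; within the scatter), upward and of modest size, roughly matching where compound 3 already stands with 2500000 nM. Compound 4 is thus expected at about 2000000 nM, within 900000 nM to 5000000 nM.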

Compound 4, half-maximal cytotoxic concentration: 545000 nM
Compound 4: the middle estimate sits 3.7-fold (0.56 log units) above what was measured; the whole stated range lies above it.
By their numbers in this assay, from the lowest: compound 4; then compound 2; then compound 3.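

Among these compounds, the saturated ring carbon is not a silent position in this assay: a 2.1-fold lower number from compound 2 to compound 4 (0.33 log units; beyond the scatter), and this is the first step that isolates a change there. Among the compounds shown here, the step runs downward, so with the rest of the structure held constant, hydroxy in place of azido goes with higher toxicity in this test, and compound 4 gives 545000 nM, the lowest number so far. The azido group, with its larger heavy-atom count, therefore sits on the less toxic side of this one pair, although nothing measured here bears on the cause of the step.

From the compounds shown here alone, what an amine or a fluoro group on the same ring carbon would give remains open. This single pair also cannot show whether the step carries over to the core of compound 3.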